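The compounds below may be only part of what the source reports. "The series", "measured", "known", "first", "only" and "open" are said of these compounds alone.

Measured in an ADME assay (liver) for metabolic stability, with Liver microsome (Homo sapiens) as the target, read by LC-MS, using microsomes, with a stated time of 1 h, tested at 5 uM; a lower number here means that less of the compound is left, a higher number that more of the compound is left:
compound 1 `Cc1nc(-c2ccccc2)c(C(=O)N2CCN(c3cccc(Cl)c3)CC2)o1`: 13.5%
compound 2 `Cc1ccc(C)c(N2CCN(C(=O)c3oc(C)nc3-c3ccccc3)CC2)c1`: 33.8%
compound 3 `Cc1nc(-c2ccc(F)cc2)c(C(=O)N2CCN(c3cc(Cl)cc(Cl)c3)CC2)o1`: 71.8%

Compound 1 stands lowest of the three. Still unmeasured is compound 4 `Cc1nc(-c2ccccc2)c(C(=O)N2CCN(c3cc(Cl)cc(Cl)c3)CC2)o1`, reached from compound 1 by chloro in place of hydrogen on an aromatic carbon, meta to a chloro group, so 3-chlorophenyl becomes 3,5-dichlorophenyl. One measured step changes that same group: a number 20.3 percentage points higher from compound 1 to compound 2 (beyond the scatter). Compound 3 also carries 3,5-dichlorophenyl and gives 71.8%, but it differs from compound 1 elsewhere too, so it is only a loose guide. An upward step beyond the scatter is therefore expected in this assay, somewhat larger than the modest one. The estimated step is a number 31.5 percentage points higher from compound 1 to compound 4 (beyond the scatter). For compound 4 the expected value is 45%, with an estimated range of 25% to 70%.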

Compound 4, percent of the compound remaining: 66.3%
Compound 4: middle estimate off by 21.3 percentage points, on the low side, and the stated range covers the measured number.
By their numbers in this assay, from the lowest: compound 1; then compound 2; then compounds 4 and 3 (each within the scatter of the next).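

In this assay, the second chloro alone gives a number 52.8 percentage points higher from compound 1 to compound 4 (beyond the scatter), so the gain seen with 3,5-dichlorophenyl does not need any other change to the core. Against 2,5-dimethylphenyl, the same group gives a number 32.5 percentage points higher from compound 2 to compound 4 (beyond the scatter), so two substituents on this ring do not by themselves set the level. Hydrogen in place of fluoro gives a number 5.5 percentage points lower from compound 3 to compound 4 (within the scatter), so with 3,5-dichlorophenyl present the fluoro makes no readable difference. Nothing here bears on why the second chloro has this effect. Going by these compounds, whether trifluoromethyl or nitrile in the same place would match chloro remains open.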